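Furan for Thiophene at the Aromatic Carbon

A few compounds are considered here, and "the series" means these few. Any claim that something is new, unique, unknown or untested is made for them only; others in the source may bear on it.

Compound 1 `CC(C)c1ccc(-c2sc(N)c(C(=O)c3ccc(Cl)cc3)c2CC(C)(C)C)cc1` and compound 2 `CC(C)(C)Cc1c(-c2cccs2)sc(N)c1C(=O)c1ccc(Cl)cc1` share one core and differ only in the group attached at a single aromatic carbon. In an assay on CHO cells for displacement of a labelled ligand from adenosine receptor A1 (Homo sapiens), read by scintillation counting, tested at 10 uM (a higher number here means more inhibition at the concentration tested (going by the name of the read-out), a lower number less inhibition), compound 1 gives 1%, and compound 2 gives 1%. The step of no change at the digits printed from compound 1 to compound 2 (within the scatter) therefore amounts to no change within the scatter, so compound 2 stands level with compound 1 on the numbers shown, with essentially no inhibition at the concentration tested.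

Compound 3 `CC(C)(C)Cc1c(-c2ccco2)sc(N)c1C(=O)c1ccc(Cl)cc1` alters the same aromatic carbon once more: furan-2-yl in place of thiophen-2-yl on an aromatic carbon. Among the compounds with values here, the only measured step bearing on this position, from compound 1 to compound 2, was flat within the scatter even though it swapped a six-membered ring for a five-membered one. Compound 3 is therefore expected to show no change at the digits printed from compound 2 to compound 3 (within the scatter), that is, no movement beyond the scatter. The estimated value for compound 3 in this assay is 1%, with a range from 0% to 10%.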

Compound 3, a percentage reported as inhibition, at one concentration (the size of the read-out at that concentration, not a potency): 1%
Compound 3: middle estimate and measured number agree at the digits printed, and the stated range covers the measured number.
By their numbers in this assay, from the lowest: compounds 1, 2 and 3 (each within the scatter of the next).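

Putting furan-2-yl in place of thiophen-2-yl swaps only the hetero atom of a five-membered aromatic ring, and in this assay this gives no change at the digits printed from compound 2 to compound 3 (within the scatter). The wider swap of furan-2-yl in place of 4-isopropylphenyl reads the same, no change at the digits printed from compound 1 to compound 3 (within the scatter), so three different groups at this aromatic carbon now stand level, all with almost no inhibition. No supporting data are available to explain this flat result.

From the compounds shown here alone, with all three values so close to the bottom of the read-out, it remains open whether this position matters at all or whether the shared core gives little inhibition whatever sits there. An amine or a carboxylic acid on this carbon, or a shorter chain in place of the neopentyl group, could help to separate the two.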